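Moving the Trifluoromethyl Group on a Shared Core

The source may hold more compounds than are shown below. What is called first, only, known or untested is meant among the compounds shown, and "the series" means these compounds.

Compound 1 `Oc1ccc(-c2cc(-c3ccccc3C(F)(F)F)cc(-c3ccccc3O)n2)cc1` gives 8990 nM in a functional assay on HCT-15 cells (Homo sapiens) for inhibition; on this read-out higher numbers stand for weaker inhibition and lower numbers for stronger inhibition. Compound 2 `Oc1ccc(-c2cc(-c3cccc(C(F)(F)F)c3)cc(-c3ccccc3O)n2)cc1` reaches only the limit of this assay, > 50000 nM. Compound 3 `Oc1cccc(-c2cc(-c3ccccc3C(F)(F)F)cc(-c3cccc(O)c3)n2)c1` gives 8150 nM in this assay.

Compounds 1 and 3 carry their hydroxyl groups differently; how the two cores differ is not broken down here, and their values in this assay sit within the usual scatter of each other. From compound 1 to compound 2 a single change is made: 3-(trifluoromethyl)phenyl in place of 2-(trifluoromethyl)phenyl on an aromatic carbon. This produced an at least 5.5-fold higher number from compound 1 to compound 2 (0.74 log units; beyond the scatter), a step resting on a limit (the limit of > 50000 nM in this assay, at which 1 of the 3 values shown sits).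

Compound 4 `Oc1cccc(-c2cc(-c3cccc(C(F)(F)F)c3)cc(-c3cccc(O)c3)n2)c1` has not yet been measured. It arises from compound 3 by the same kind of change: 3-(trifluoromethyl)phenyl in place of 2-(trifluoromethyl)phenyl on an aromatic carbon. The surroundings are not identical: in compound 3 the place is meta to two 3-hydroxyphenyl groups, whereas in compound 1 it is meta to a 2-hydroxyphenyl group and meta to a 4-hydroxyphenyl group.

For compound 4 a step like the earlier one is expected, a 6.1-fold higher number from compound 3 to compound 4 (0.79 log units; beyond the scatter), because the same kind of change gave an at least 5.5-fold higher number from compound 1 to compound 2 (0.74 log units; beyond the scatter). Compound 4 is therefore estimated at 50000 nM, expected to fall between 20000 nM and 150000 nM, with a real chance that this assay again reports only a limit.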

Compound 4, half-maximal inhibitory concentration: 13600 nM
Compound 4: middle estimate off by 3.7-fold (0.57 log units), on the high side, and the stated range ends above it.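

On the core of compound 3, the same move of the trifluoromethyl group gives a 1.7-fold higher number from compound 3 to compound 4 (0.22 log units; within the scatter) in this assay, so a step seen on one core did not carry over at the same size to the other: the same change on two cores in this assay, an at least 5.5-fold higher number (0.74 log units; beyond the scatter) from compound 1 to compound 2 and a 1.7-fold higher number (0.22 log units; within the scatter) from compound 3 to compound 4, at least 3.3-fold (0.52 log units) apart, beyond the scatter of two such steps.

The earlier step has no exact size, since it rests on a limit, that of compound 2, and not on a number: the limit of > 50000 nM in this assay, at which 1 of the 4 values shown sits.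

For the compounds shown here, the result shows that, in this series, the effect of swapping 2-(trifluoromethyl)phenyl for 3-(trifluoromethyl)phenyl depends on the core it sits on, but with only two cores it does not show which feature of those cores is responsible, or why.

The compounds shown leave open how the same swap would behave on a core with an amine or a carboxylic acid in place of the hydroxyl groups. They also leave open whether a nitrile in place of the trifluoromethyl group would show the same dependence on the core.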